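The source may report more compounds than this note shows. Statements on the series, on what has been measured and on what is new or still open speak of the compounds shown alone.

Measured compounds:
Compound 1, `CCOc1ccc(-c2c(C#N)c(N)nc(SCc3ccn[nH]3)c2C#N)cc1`, gives 18% in an assay on CHO cells for displacement of a labelled ligand from adenosine receptor A3 (Homo sapiens), read by scintillation counting, with a stated time of 120 min, tested at 1 uM; a higher number here means more inhibition at the concentration tested (going by the name of the read-out), a lower number less inhibition.
Compound 2, `CC(C)COc1ccc(-c2c(C#N)c(N)nc(SCC(N)=O)c2C#N)cc1`, gives 9% in this assay.
Compound 3, `CNC(=O)CSc1nc(N)c(C#N)c(-c2ccc(OCC3CC3)cc2)c1C#N`, gives 3% in this assay.

All three share a core and differ in the group on the sulfur and in the chain on the aromatic oxygen. On the numbers at hand, compound 2 stands second highest of the three, but its nearest neighbour, compound 3, lies within the scatter, and so does the furthest, compound 1; nothing can be ordered among them, and none can be called stronger or weaker than another.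

Compound 4, `N#Cc1c(N)nc(SCC(N)=O)c(C#N)c1-c1ccc(OCC2CCC2)cc1`, has not yet been measured. It differs from compound 2 in one place: cyclobutyl in place of isopropyl on a saturated chain carbon bound to an oxygen on an aromatic ring. Within the data shown here, no step between two measured compounds isolates such a change, so nothing measured tells how this swap acts on its own.

With the three measured values all within the scatter of one another and nothing measured speaking to the change, the step from compound 2 to compound 4 is expected to be no change at the digits printed from compound 2 to compound 4 (within the scatter) in this assay, that is, no change beyond the scatter. Compound 4 is therefore estimated at 9%, with a range from 0% to 25%.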

Compound 4, a percentage reported as inhibition, at one concentration (the size of the read-out at that concentration, not a potency): 1%
Compound 4: middle estimate off by 8 percentage points, on the high side; low and high end bracket the measured number.
By their numbers in this assay, from the lowest: compounds 4, 3, 2 and 1 (each within the scatter of the next, the first and the last beyond it).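

Among these compounds, this is the first direct reading of the swap at this place, on a saturated chain carbon bound to an oxygen on an aromatic ring: in this assay, it gives a number 8 percentage points lower from compound 2 to compound 4 (within the scatter). Replacing isopropyl with cyclobutyl brings in a four-membered ring of carbon only, yet the read-out does not separate compound 2 at 9% from compound 4 at 1%, so this swap does not raise inhibition beyond the scatter at the concentration tested, and with both numbers this small, the assay gives no sign that the ring matters here. No measurement on hand explains this result.

The compounds shown leave open how an amine, a carboxylic acid or a longer chain would read at this place, since the groups compared here are both made of carbon only. Among the compounds shown here, they also leave open whether cyclobutyl in place of isopropyl would read the same with another group on the sulfur, such as the one in compound 1, rather than the group shared by compound 2 and compound 4.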